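Removing a Trifluoromethoxy Group from a Furoic Acid Biphenyl Ether

The source may report more compounds than this note shows. Statements on the series, on what has been measured and on what is new or still open speak of the compounds shown alone.

Measured so far:
Compound 1, `CC(=O)c1ccc(-c2ccc(OCc3cc(C(=O)O)oc3C)cc2)cc1`: 150 nM
Compound 2, `Cc1oc(C(=O)NS(=O)(=O)c2ccccc2)cc1COc1ccc(-c2ccccc2)cc1`: 25 nM
Compound 3, `Cc1oc(C(=O)O)cc1COc1ccc(-c2ccc(OC(F)(F)F)cc2)cc1`: 2400 nM

In an assay on cells for displacement of a labelled ligand from prostaglandin E2 receptor EP4 subtype (Homo sapiens), read by scintillation counting (on this read-out lower numbers stand for stronger inhibition and higher numbers for weaker inhibition), compound 3 gives the highest of the three numbers; compound 1 is nearest to it and compound 2 furthest from it. The step from compound 3 to compound 4, `Cc1oc(C(=O)O)cc1COc1ccc(-c2ccccc2)cc1`, is hydrogen in place of trifluoromethoxy on an aromatic carbon. Among the compounds with values here, the only measured step that touches this position is a 16-fold higher number from compound 1 to compound 3 (1.20 log units; beyond the scatter), which shows that what sits on this aromatic carbon, para to a large group, moves the number strongly. Within the data shown here, no measured pair shows hydrogen against trifluoromethoxy directly, and compound 2 differs from compound 4 at the acid as well. Compound 4 is therefore expected to give a lower number than compound 3, with an estimated step of a 12-fold lower number from compound 3 to compound 4 (1.08 log units; beyond the scatter), so that compound 4 is estimated at 200 nM, between 50 nM and 800 nM.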

Compound 4, inhibition constant: 420 nM
The estimate for compound 4 lay 2.1-fold (0.32 log units) below the measured number; low and high end bracket the measured number.
By their numbers in this assay, from the lowest: compound 2; then compound 1; then compound 4; then compound 3.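

With a 5.7-fold lower number from compound 3 to compound 4 (0.76 log units; beyond the scatter) on going to hydrogen, trifluoromethoxy on this aromatic carbon is shown to carry a higher number than no substituent at all. Acetyl at the same place falls on the other side of hydrogen, with a 2.8-fold higher number from compound 1 to compound 4 (0.45 log units; beyond the scatter) on losing it. Within the data shown here, at the carbonyl carbon, a 17-fold higher number from compound 2 to compound 4 (1.23 log units; beyond the scatter) gives the first direct reading of hydroxy against (phenylsulfonyl)amino. Nothing measured here accounts for these steps. On these data alone, whether an amine or a nitrile on this aromatic carbon would side with acetyl or with trifluoromethoxy stays open, as does whether (phenylsulfonyl)amino would give a similar step on compound 1.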